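A few compounds are considered here, and "the series" means these few. Any claim that something is new, unique, unknown or untested is made for them only; others in the source may bear on it.

Compound 1 `Nc1cc(N)c2nc(-c3ccccc3)c(Sc3ccc(F)cc3)nc2c1` gives 83200 nM in a functional assay on EKVX cells (Homo sapiens) for inhibition, read by sulforhodamine B assay, with a stated time of 48 h; on this read-out lower numbers stand for higher toxicity in this test and higher numbers for lower toxicity in this test. Compound 2 `Nc1cc(N)c2nc(-c3ccccc3)c(Oc3ccc(F)cc3)nc2c1` gives 77600 nM in this assay. Compound 3 `CCOC(=O)[C@H](CCC(=O)O)NC(=O)c1ccc(Oc2nc3cc(N)cc(N)c3nc2-c2ccccc2)cc1` reaches only a limit of the assay, < 100000 nM in this assay.

Compound 2 holds the lowest of the two numbers; its nearest neighbour is compound 1, and a 1.1-fold lower number from compound 1 to compound 2 (0.03 log units; within the scatter) lies within the scatter. Compound 4 `Nc1cc(N)c2nc(-c3ccccc3)c(NCc3ccc(F)cc3)nc2c1` differs from compound 2 by (4-fluorobenzyl)amino in place of 4-fluorophenoxy on an aromatic carbon. For the measured compounds named here, the only measured step at this position, a 1.1-fold lower number from compound 1 to compound 2 (0.03 log units; within the scatter), shows that swapping the linking atom there barely moved the read-out, so no step beyond the scatter is expected for compound 4 in this assay; the expected step is a 1.1-fold lower number from compound 2 to compound 4 (0.04 log units; within the scatter). Compound 4 is therefore estimated at 70000 nM, with a range from 30000 nM to 150000 nM.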

Compound 4, concentration lethal to 50% of the cells: 8710 nM
Beside the measured number, compound 4's estimate is 8.0-fold (0.91 log units) above it, and the stated range ends above it.
By their numbers in this assay, from the lowest: compound 4; then compounds 2 and 1 (each within the scatter of the next).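

At the aromatic carbon next to the ring nitrogen, the read-out does respond to the group carried there: in this assay the change gives an 8.9-fold lower number from compound 2 to compound 4 (0.95 log units; beyond the scatter) and a 9.6-fold lower number from compound 1 to compound 4 (0.98 log units; beyond the scatter) for the two earlier linked groups. Unlike 4-fluorophenoxy, (4-fluorobenzyl)amino brings a hydrogen-bond donor, but nothing at hand accounts for these steps.

From the compounds shown here alone, whether the amine nitrogen or the benzyl carbon carries the change stays open. An anilino group or a phenethylamino chain at this position could separate the two.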